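Extending the Ether from Ethoxy to Isopropoxy

This account rests on a few compounds, and the source may have more. Where it says the series, first, only, none or still open, it means among the compounds named here.

compound 1 `COc1ccc(C#Cc2ccc(C(=O)N3CCC[C@@H](CO)C3)cc2)cc1F`: > 10000 nM
compound 2 `CCOc1ccc(C#Cc2ccc(C(=O)N3CCC[C@@H](CO)C3)cc2)cc1`: > 10000 nM

In a functional assay on TREX cells for negative allosteric modulation of metabotropic glutamate receptor 3 (Rattus norvegicus), read by calcium flux, with a stated time of 2.5 min (on this read-out higher numbers stand for weaker inhibition and lower numbers for stronger inhibition), compound 1 gives > 10000 nM, which is a limit of the assay, not a number. In this assay compound 2 likewise gives > 10000 nM, again a limit. The step that the two limits leave unreadable from compound 1 to compound 2 is therefore unreadable. Compound 2 thus stands at the limit, where both values shown sit (the limit of > 10000 nM in this assay, at which 2 of the 2 values shown sit). Compound 3 `CC(C)Oc1ccc(C#Cc2ccc(C(=O)N3CCC[C@@H](CO)C3)cc2)cc1` differs from compound 2 by methyl in place of hydrogen on a saturated chain carbon bound to an oxygen on an aromatic ring and a saturated chain carbon. No measured step bears on this change, and the single step shown gave no size. Compound 3 is expected to give 15000 nM (range 3000 nM to 60000 nM). The expected step that the limit leaves unreadable from compound 2 to compound 3 is thus no step beyond the scatter, with the result most likely again a limit.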

Compound 3, half-maximal inhibitory concentration: > 10000 nM
Compound 3 gave a limit, no number; the forecaster's own chance of this, stated with the estimate: 80%; the middle value lies beyond the limit too.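

Within the data shown here, compound 3, like compound 2, gives only a limit and not a number, so no step between them can be read. The compounds shown leave open whether ethoxy to isopropoxy changes inhibition at all in this assay.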